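The source may hold more compounds than are shown below. What is called first, only, known or untested is meant among the compounds shown, and "the series" means these compounds.

In a functional assay on HepG2 cells (Homo sapiens) for cytotoxicity, read by MTT assay, with a stated time of 72 h (a higher number here means a weaker inhibitor, a lower number a stronger inhibitor), compound 1 (`Nc1ccccc1NC(=O)c1ccc(NC(=S)NCc2cccnc2)cc1`) gives 4200 nM and compound 2 (`Nc1ccccc1NC(=O)c1ccc(NC(=S)NCc2cncc(F)c2)cc1`) gives 13000 nM as the higher number of the two. Going by the values given here, the only measured step is a 3.1-fold higher number from compound 1 to compound 2 (0.49 log units; beyond the scatter) and comes with fluoro in place of hydrogen on an aromatic carbon. Compound 3 (`Nc1ccccc1NC(=O)c1ccc(NC(=S)NCc2cccc(Cl)c2)cc1`) differs from compound 2 more widely (3-chlorophenyl in place of 5-fluoropyridin-3-yl on a saturated chain carbon bound to an amide-type nitrogen) with 3-chlorophenyl in place of 5-fluoropyridin-3-yl on a saturated chain carbon bound to an amide-type nitrogen. Among the compounds with values here, the measured step bears on this change only in part: the fluoro leaves again, but no compound here shows the effect of the chlorine or of the carbon-only ring. With the fluoro gone, a return toward compound 1 at 4200 nM seems the likeliest course. The expected move is a 2.2-fold lower number from compound 2 to compound 3 (0.34 log units; beyond the scatter) and would be modest in size. In this assay the estimate for compound 3 is 6000 nM with 1800 nM to 15000 nM as its expected range.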

Compound 3, half-maximal inhibitory concentration: 2600 nM
The estimate for compound 3 lay 2.3-fold (0.36 log units) above the measured number, and the stated range covers the measured number.
By their numbers in this assay, from the lowest: compounds 3 and 1 (each within the scatter of the next); then compound 2.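

In this assay, this position bound to the amide-type nitrogen also accepts a carbon-only ring: 3-chlorophenyl in place of 5-fluoropyridin-3-yl gives a 5.0-fold lower number from compound 2 to compound 3 (0.70 log units; beyond the scatter), a larger step than the one seen for the fluoro alone. Set against the unfluorinated ring, 3-chlorophenyl in place of pyridin-3-yl gives a 1.6-fold lower number from compound 1 to compound 3 (0.21 log units; within the scatter), so among these three compounds only compound 2 stands apart, and the ring nitrogen can be exchanged for a carbon-only ring bearing chlorine without a change beyond the scatter. Nothing at hand explains these differences.

On these data alone, the chlorine and the carbon-only ring enter together, so their separate shares in the step remain open. Also open, as far as these compounds go, is what a plain phenyl, a methoxy group in place of the chlorine or a longer chain at the saturated carbon would give.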